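Halogen change from compound 3 to compound 4

The compounds below may be only part of what the source reports. "The series", "measured", "known", "first", "only" and "open" are said of these compounds alone.

In a functional assay on Ehrlich cells (Mus musculus) for cytotoxicity, read by LDH release, with a stated time of 48 h (a lower number here means a stronger inhibitor, a higher number a weaker inhibitor), compound 1 `Cc1cc(C(=O)c2ccccc2)ccc1OCC(=O)Nc1nc(-c2ccccc2)cs1` gives 24500 nM, compound 2 `Cc1ccc(C(=O)c2ccc(OCC(=O)Nc3nc(-c4ccccc4)cs3)c(C)c2)cc1` gives 30500 nM and compound 3 `Cc1cc(C(=O)c2ccc(F)cc2)ccc1OCC(=O)Nc1nc(-c2ccccc2)cs1` gives 38600 nM. These three values lie within the scatter of one another, so compound 3 does not stand apart from the other two.

Compound 4 `Cc1cc(C(=O)c2cccc(Br)c2)ccc1OCC(=O)Nc1nc(-c2ccccc2)cs1` carries 3-bromophenyl in place of 4-fluorophenyl on a carbonyl carbon. Among the measured compounds shown here, no measured compound carries 3-bromophenyl, so the evidence is indirect. For the measured compounds named here, three measured steps bear on the change, each a substitution on an aromatic carbon and each within the scatter. Fluoro in place of hydrogen gave a 1.6-fold higher number from compound 1 to compound 3 (0.20 log units; within the scatter), methyl in place of hydrogen gave a 1.2-fold higher number from compound 1 to compound 2 (0.10 log units; within the scatter), and fluoro in place of methyl gave a 1.3-fold higher number from compound 2 to compound 3 (0.10 log units; within the scatter).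

With steps this small, no shift beyond the scatter is expected in this assay, and no direction can be favoured with confidence. The expected change is a 1.2-fold lower number from compound 3 to compound 4 (0.10 log units; within the scatter). Compound 4 is estimated at 31000 nM, with an expected range of 15000 nM to 62000 nM.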

Compound 4, half-maximal inhibitory concentration: 25900 nM
The estimate for compound 4 lay 1.2-fold (0.08 log units) above the measured number, and the stated range covers the measured number.
By their numbers in this assay, from the lowest: compounds 1, 4, 2 and 3 (each within the scatter of the next).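

The change from 4-fluorophenyl to 3-bromophenyl on the carbonyl carbon alters both the halogen and its ring position in one step, and it gives a 1.5-fold lower number from compound 3 to compound 4 (0.17 log units; within the scatter). The other two comparisons read the same way, with a 1.2-fold lower number from compound 2 to compound 4 (0.07 log units; within the scatter) and a 1.1-fold higher number from compound 1 to compound 4 (0.02 log units; within the scatter), so all four aryl groups at this position sit within the scatter of one another in this assay. No supporting data are available to explain this flat reading.

As far as these compounds go, it remains open whether the flat reading extends to other kinds of group on this carbonyl carbon, such as an aminophenyl or carboxyphenyl group, or a longer chain in place of the aryl group. A 4-bromophenyl or 3-fluorophenyl group would separate the change of halogen from the change of ring position.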